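Extending the amide substituent of compound 2 toward a glutamine-like side chain

A few compounds are considered here, and "the series" means these few. Any claim that something is new, unique, unknown or untested is made for them only; others in the source may bear on it.

Measured compounds:
- compound 1, `COc1cc2c(cc1O)CCC(C)(CC(=O)N[C@@H](C)C(=O)O)O2`, 68.5%
- compound 2, `COc1cc2c(cc1O)CCC(C)(CC(N)=O)O2`, 51.4%

Both compounds share one core and differ only at an amide-type nitrogen. In an ADME assay on SH-SY5Y cells (Homo sapiens) for cytotoxicity, read by MTT assay, with a stated time of 24 h, tested at 100 uM (a higher number here means a weaker effect of the compound at the concentration tested, a lower number a stronger effect), compound 1 gives 68.5%, while compound 2 gives 51.4%. Compound 2 stands lowest of the two numbers, and the step of a number 17.1 percentage points lower from compound 1 to compound 2 (beyond the scatter) lies beyond the scatter.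

Compound 3, `COc1cc2c(cc1O)CCC(C)(CC(=O)N[C@@H](CCC(N)=O)C(=O)O)O2`, has not yet been measured. It differs from compound 2 by 3-carbamoyl-1-carboxypropyl in place of hydrogen on an amide-type nitrogen.

Going by the values given here, only one measured step bears on this change: a number 17.1 percentage points lower from compound 1 to compound 2 (beyond the scatter), which removed 1-carboxyethyl from the same nitrogen and lowered the number. Compound 3 puts a group of similar kind, 3-carbamoyl-1-carboxypropyl, back onto that nitrogen, so a rise of comparable size is expected, in the opposite direction to that step. The expected step is a number 14.6 percentage points higher from compound 2 to compound 3 (beyond the scatter). For compound 3 the estimate in this assay is 66%, with a range from 52% to 80%.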

Compound 3, a percentage reported as activity, at one concentration (the size of the read-out at that concentration, not a potency): 58.2%
Beside the measured number, compound 3's estimate is 7.8 percentage points above it, and the stated range covers the measured number.
By their numbers in this assay, from the lowest: compounds 2 and 3 (each within the scatter of the next); then compound 1.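

Placed on the amide-type nitrogen in this assay, 3-carbamoyl-1-carboxypropyl gives a much smaller shift than the one seen with 1-carboxyethyl (a number 17.1 percentage points lower from compound 1 to compound 2 (beyond the scatter)): the new step is a number 6.8 percentage points higher from compound 2 to compound 3 (within the scatter) and so cannot be told apart from the unsubstituted amide. The two substituents on this nitrogen are therefore not interchangeable, since carbamoylmethyl in place of hydrogen on a saturated chain carbon, two bonds along the chain from an amide-type nitrogen and a carbonyl carbon, gives a number 10.3 percentage points lower from compound 1 to compound 3 (beyond the scatter) and thus a real difference between two closely related side chains. Nothing available explains why this added piece of side chain changes the read-out.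

From the compounds shown here alone, it remains open whether the carbamoyl itself or the added chain length accounts for that difference, and a carboxylic acid in place of the carbamoyl or a plain butyl-type carbon chain would help separate the two. Going by these compounds, how an amine on the side chain, or a longer chain carrying the same carbamoyl, would read in this assay also remains unknown.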